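Sulfonamides on a Shared Core and a Chloro-Methoxy Variant

The source may report more compounds than this note shows. Statements on the series, on what has been measured and on what is new or still open speak of the compounds shown alone.

Measured so far:
compound 1 `O=S(=O)(Nc1ccc2oc(-c3ccccc3)nc2c1)c1ccccc1O` — > 63000 nM
compound 2 `COc1ccc(S(=O)(=O)Nc2ccc(-c3nc4ccccc4o3)cc2)cc1` — > 63000 nM
compound 3 `O=S(=O)(Nc1ccc(-c2nc3ccccc3o2)cc1)c1cccc(Cl)c1` — > 63000 nM

In an assay on isolated protein for inhibition of malate dehydrogenase, mitochondrial (Sus scrofa), with stated times of 45 min and 30 min (on this read-out higher numbers stand for weaker inhibition and lower numbers for stronger inhibition), compound 1 gives no number but only the limit of the assay, > 63000 nM. Compound 2 likewise stops at a limit, > 63000 nM. Compound 3 also stops at a limit, > 63000 nM. For the measured compounds named here, the one step between measured compounds that differ in a single place, a step that the two limits leave unreadable from compound 2 to compound 3, cannot be read because of the limit of > 63000 nM in this assay, at which 3 of the 3 values shown sit. Compound 1 therefore stands nowhere on a scale of numbers; it sits at the same limit as the other two, and no ordering among the three can be drawn.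

Compound 4 `COc1ccc(Cl)cc1S(=O)(=O)Nc1ccc2oc(-c3ccccc3)nc2c1` differs from compound 1 by 5-chloro-2-methoxyphenyl in place of 2-hydroxyphenyl on a sulfonyl sulfur. Going by the values given here, none of the measured compounds carries this change, and the single measured step offers no readable size, so no step is available to transfer to this pair. Given that every value seen so far sits at the limit, compound 4 is expected to behave the same way, with a step that the limit leaves unreadable from compound 1 to compound 4 that is not expected to move beyond the scatter of this assay. The estimate for compound 4 is 100000 nM, with a range from 30000 nM to 400000 nM, most likely reported as a limit rather than a number.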

Compound 4, half-maximal inhibitory concentration: > 63000 nM
Compound 4: no number, only a limit (the forecaster's own chance of this, stated with the estimate: 85%); the middle value lies beyond the limit too.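

In this assay compound 4 also gives only a limit, > 63000 nM, so the change from compound 1 to compound 4 yields no readable step, and this holds because every result is a limit: the limit of > 63000 nM in this assay, at which 4 of the 4 values shown sit.

The compounds shown leave open how far each lies beyond that limit, and whether any change on the sulfonyl sulfur alters inhibition at all.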